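From dodecyl to tert-butyl on the shared core

The source may hold more compounds than are shown below. What is called first, only, known or untested is meant among the compounds shown, and "the series" means these compounds.

Going by the values given here, in a functional assay on MCF7 cells (Homo sapiens) for antiproliferative activity, read by MTT assay, with a stated time of 48 h (on this read-out higher numbers stand for weaker inhibition and lower numbers for stronger inhibition), compound 2 (`CCCCCCCCCCCCNc1nc2ccccc2nc1Oc1ccc(C(=O)N[C@@H](C)C(=O)O)cc1`) gives 4110 nM and stands as the lower of the two numbers so far, while compound 1 (`CC[C@@H](C)[C@H](NC(=O)c1ccc(Oc2nc3ccccc3nc2NC(C)(C)C)cc1)C(=O)OC`) gives 33400 nM as the higher one. Compound 3 (`C[C@H](NC(=O)c1ccc(Oc2nc3ccccc3nc2NC(C)(C)C)cc1)C(=O)O`) carries tert-butyl in place of dodecyl on a nitrogen on an aromatic ring. Among the compounds with values here, no measured pair isolates this change. Compound 1 also carries tert-butyl and gives 33400 nM in this read-out. The expected step in this assay is a 5.4-fold higher number from compound 2 to compound 3 (0.73 log units; beyond the scatter) toward weaker inhibition and beyond the scatter. Compound 3 is estimated at 22000 nM (expected range 8000 nM to 60000 nM).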

Compound 3, half-maximal inhibitory concentration: 29400 nM
Compound 3: middle estimate off by 1.3-fold (0.13 log units), on the low side; the range from low to high includes it.
By their numbers in this assay, from the lowest: compound 2; then compounds 3 and 1 (each within the scatter of the next).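

In this assay, tert-butyl in place of dodecyl on a nitrogen on an aromatic ring gives a 7.2-fold higher number from compound 2 to compound 3 (0.85 log units; beyond the scatter) on the shared core, so the group at this nitrogen sets a step beyond the scatter. With tert-butyl in place, 1-carboxyethyl in place of 1-(methoxycarbonyl)-2-methylbutyl on an amide-type nitrogen gives a 1.1-fold lower number from compound 1 to compound 3 (0.06 log units; within the scatter) and does not separate the two compounds. No available evidence explains either step.

Open, on these data alone, is whether a hexyl chain on this nitrogen would fall between compound 2 and compound 3. Also open, as far as these compounds go, is whether a methyl ester in place of the carboxylic acid would shift compound 2 with dodecyl present.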